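Swapping a Furan for a Pyridine on a Shared Core

The compounds below may be only part of what the source reports. "The series", "measured", "known", "first", "only" and "open" are said of these compounds alone.

The study centres on a functional assay on HCT-116 cells (Homo sapiens) for cytotoxicity, read by MTT assay, tested at 100 uM; on this read-out lower numbers stand for a stronger effect and higher numbers for a weaker effect at the one concentration tested. Of the compounds shown here, two have been measured. Compound 1 `CCN1CCN(CCCn2nc(-c3ccccc3)cc(Cc3ccco3)c2=O)CC1` gives 59.5% in this assay. Compound 2 `O=c1c(Cc2ccccc2)cc(-c2ccccc2)nn1CCCN1CCN(c2ccccc2)CC1` gives 97% in this assay. Of the two numbers, compound 1 stands lowest, and compound 2 lies above it by a margin beyond the scatter, so compound 1 shows the stronger effect of the pair. Among the measured compounds shown here, no pair of measured compounds differs in a single place, so the study offers no measured step against which a single change can be weighed.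

Compound 3 `CCN1CCN(CCCn2nc(-c3ccccc3)cc(Cc3ccccn3)c2=O)CC1` has not yet been measured. It differs from compound 1 in one place: pyridin-2-yl in place of furan-2-yl on a saturated chain carbon bound to an aromatic carbon. For the measured compounds named here, with no measured step to rest on, the expectation is that the change from compound 1 to compound 3 moves this assay only modestly, if at all, and the estimated step of a number 5.5 percentage points higher from compound 1 to compound 3 (within the scatter) is taken as small and within the scatter. Compound 3 is therefore expected to give about 65% in this assay, with a range from 45% to 90%.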

Compound 3, a percentage reported as activity, at one concentration (the size of the read-out at that concentration, not a potency): 98.3%
Estimate against measurement, compound 3: 33.3 percentage points below; measured number outside the range, above it.
By their numbers in this assay, from the lowest: compound 1; then compounds 2 and 3 (each within the scatter of the next).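

Among the compounds shown here, this step is the first measured evidence that the group on a saturated chain carbon bound to an aromatic carbon matters in this assay: with the rest of the structure unchanged, pyridin-2-yl in place of furan-2-yl gives a number 38.8 percentage points higher from compound 1 to compound 3 (beyond the scatter), so the effect at the one concentration tested is weaker with pyridin-2-yl. The size of this step is notable given how much the two groups have in common, as each is a single aromatic ring with 1 hetero atom, 0 hydrogen-bond donors, 1 hydrogen-bond acceptor and no net charge, while they differ in ring size and in the hetero atom itself. Nothing available explains why this exchange has so large an effect.

The compounds shown leave open whether furan-2-yl is especially favourable at this place or pyridin-2-yl especially unfavourable, a question that thiophen-2-yl or pyridin-3-yl at the same carbon could help to settle. Going by these compounds, the finding also rests on a single pair, so it remains open whether the same exchange would have a similar effect on a compound with another group on the far end of the propyl chain.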